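The source may report more compounds than this note shows. Statements on the series, on what has been measured and on what is new or still open speak of the compounds shown alone.

Compound 1 `CNC(=O)c1cc(Oc2ccc(NC(=O)c3cc4cccnc4n(-c4ccccc4F)c3=O)cc2)ccn1` gives 260 nM in a functional assay on HT-29 cells (Homo sapiens) for antiproliferative activity, read by MTT assay, with a stated time of 72 h (a higher number here means a weaker inhibitor, a lower number a stronger inhibitor), which is the highest of the two numbers measured; its nearest neighbour is compound 2 `CNC(=O)c1cc(Oc2ccc(NC(=O)c3cc4cccnc4n(-c4ccc(F)cc4)c3=O)cc2)ccn1`, which gives 160 nM in the same assay. Among the measured compounds shown here, the one step between measured compounds, a 1.6-fold lower number from compound 1 to compound 2 (0.21 log units; within the scatter), moves the fluorine from the 2-fluorophenyl to the 4-fluorophenyl arrangement and stays within the scatter. Compound 3 `CNC(=O)c1cc(Oc2ccc(NC(=O)c3cc4cccnc4n(-c4ccc(F)c(Cl)c4)c3=O)cc2)ccn1` is not yet measured; relative to compound 1 the change is 3-chloro-4-fluorophenyl in place of 2-fluorophenyl on an aromatic nitrogen. For the measured compounds named here, the step from compound 1 to compound 2 bears on it, since it also shifts the fluorine to the 4-position, and it was small; the added chlorine has no measured precedent here. The expected step of a 1.5-fold lower number from compound 1 to compound 3 (0.18 log units; within the scatter) is therefore none beyond the scatter. Compound 3 is estimated at 170 nM in this assay, with a range from 60 nM to 480 nM.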

Compound 3, half-maximal inhibitory concentration: 1810 nM
Compound 3: middle estimate off by 11-fold (1.03 log units), on the low side, outside the stated range (above it).
By their numbers in this assay, from the lowest: compounds 2 and 1 (each within the scatter of the next); then compound 3.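

The fluorine arrangements in compound 1 and compound 2 had suggested that this group on the aromatic nitrogen tolerates change, but the chlorine shows that it does not tolerate every change in this assay. Among the compounds shown here, the clearest reading is the single change of chloro in place of hydrogen on an aromatic carbon (an 11-fold higher number from compound 2 to compound 3 (1.05 log units; beyond the scatter)), a large step, whereas the comparison with the 2-fluorophenyl group, which alters more of the ring's substitution, gives a modest one (a 7.0-fold higher number from compound 1 to compound 3 (0.84 log units; beyond the scatter)). Nothing available here explains why the number rises.

The compounds shown leave open whether this rise is specific to chloro or would also follow from a methyl, a methoxy or an amine at the same place. They also leave open whether a 3-chlorophenyl group without the fluorine would give the same result.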